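From Cyclopentyl to Cyclooctyl on the Aryl Amine

The source may report more compounds than this note shows. Statements on the series, on what has been measured and on what is new or still open speak of the compounds shown alone.

Of the compounds shown here, two have been measured in a functional assay (IMR-32 cells, Homo sapiens) for inhibition, read by fluorescence, with stated times of 1 h and 13 h; on this read-out higher numbers stand for weaker inhibition and lower numbers for stronger inhibition. Compound 1 `CCNS(=O)(=O)c1ccc(NC2CCCC2)c(NCc2ccccc2)c1` gives 8.2 nM there. Compound 2 `CCNS(=O)(=O)c1ccc(NC2CCCC2)c(NCc2ccncc2)c1` gives 36 nM in this assay. Among the measured compounds shown here, compound 2 therefore holds the highest of the two numbers, and the only step that reaches it, a 4.4-fold higher number from compound 1 to compound 2 (0.64 log units; beyond the scatter), stands beyond the scatter. Compound 3 `CCNS(=O)(=O)c1ccc(NC2CCCCCCC2)c(NCc2ccncc2)c1` has not yet been measured; it differs from compound 2 by cyclooctyl in place of cyclopentyl on a nitrogen on an aromatic ring. For the measured compounds named here, no measured step concerns this site: the single measured step alters the group on a saturated chain carbon bound to a nitrogen on an aromatic ring and leaves the cyclopentyl untouched, so it offers no guide to the size or direction of the new change. With nothing to anchor a move in either direction, the expected step of a 1.1-fold higher number from compound 2 to compound 3 (0.05 log units; within the scatter) is taken as none beyond the scatter, with a wide range to allow for either outcome. On that footing compound 3 is estimated at 40 nM in this assay, between 10 nM and 160 nM.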

Compound 3, half-maximal inhibitory concentration: 22 nM
Beside the measured number, compound 3's estimate is 1.8-fold (0.26 log units) above it; the measured number falls inside the stated range.
By their numbers in this assay, from the lowest: compound 1; then compounds 3 and 2 (each within the scatter of the next).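

Among the compounds shown here, compound 3 gives the first reading at the group on the nitrogen on the aromatic ring: in this assay, cyclooctyl in place of cyclopentyl produces a 1.6-fold lower number from compound 2 to compound 3 (0.21 log units; within the scatter) and so stays within the scatter, which means the read-out does not separate the eight-membered ring from the five-membered one when pyridin-4-yl is held constant. The only earlier step, a 4.4-fold higher number from compound 1 to compound 2 (0.64 log units; beyond the scatter) in the same assay, lay beyond the scatter and was made elsewhere on the molecule, so this position is the first shown to take a change of 8 heavy atoms for 5 without a difference that the measurements can resolve. Nothing available explains why the two rings read alike.

The compounds shown leave open whether cyclohexyl, cycloheptyl or a small open chain such as isopropyl would also read alike at this nitrogen, and whether a ring carrying an amine or a carboxylic acid would be accepted there. They also leave open whether cyclooctyl would behave the same way with phenyl in place of pyridin-4-yl on the saturated chain carbon.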